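The source may report more compounds than this note shows. Statements on the series, on what has been measured and on what is new or still open speak of the compounds shown alone.

Compound 1 `CCCCCCCC/C=C/CCCCCCCC(=O)Nc1cc(C(=O)OC)c(OC)cc1OC` gives 1100 nM
Compound 2 `CCCCCCCCC(C)(C)C(=O)Nc1c(OC)cc(OC)cc1OC` gives 59 nM
Compound 3 `CCCCCCCCCCCCC(CC)C(=O)Nc1c(OC)cc(OC)cc1OC` gives 52 nM

These numbers come from an assay on microsomes from intestine for inhibition of acyl-CoA:cholesterol acyltransferase (Oryctolagus cuniculus); on this read-out higher numbers stand for weaker inhibition and lower numbers for stronger inhibition. Among the three, compound 2 stands second highest; its nearest neighbour is compound 3, whose number lies within the scatter of it, while compound 1 lies far above it, beyond the scatter. Compound 4 `CCCCCCCCCCCCCCCCC(C)(C)C(=O)Nc1c(OC)cc(OC)cc1OC` has not yet been tested. It differs from compound 2 in one place: octyl in place of hydrogen on a saturated chain carbon, nine bonds along the chain from a carbonyl carbon. Among the compounds with values here, no step between measured compounds covers this kind of change, but compound 3, which also carries a long saturated chain on the shared core, gives a number close to that of compound 2. The step from compound 2 to compound 4 is therefore expected to be small, if anything toward a slightly lower number, and likely within the scatter. Compound 4 is estimated to give 45 nM, with a range from 15 nM to 150 nM. This amounts to an expected step of a 1.3-fold lower number from compound 2 to compound 4 (0.12 log units; within the scatter).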

Compound 4, half-maximal inhibitory concentration: 87 nM
Beside the measured number, compound 4's estimate is 1.9-fold (0.29 log units) below it; the range from low to high includes it.
By their numbers in this assay, from the lowest: compounds 3, 2 and 4 (each within the scatter of the next); then compound 1.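

In this assay, octyl in place of hydrogen on a saturated chain carbon, nine bonds along the chain from a carbonyl carbon, gives a 1.5-fold higher number from compound 2 to compound 4 (0.17 log units; within the scatter). Within the data shown here, this is the first direct reading of a change at this position, and it shows that this long addition to the chain leaves the number within the scatter. Nothing measured here bears on why the number holds.

As far as these compounds go, it remains open whether a still longer chain at this position would stay this close. Also open, from the compounds shown here alone, is what a carboxylic acid or an amine at the end of the chain would do.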